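Aromatic Acetamido Group in Place of the Enamide

The compounds below may be only part of what the source reports. "The series", "measured", "known", "first", "only" and "open" are said of these compounds alone.

Compound 1, `CCOC(=O)/C=C/C(=O)N(CC(N)=O)NC(=O)[C@@H]1CCCN1C(=O)[C@H]1CCCCN1C(C)=O`: 638 nM
Compound 2, `CCOC(=O)/C=C/C(=O)N(CC(N)=O)NC(=O)[C@@H]1CCCN1C(=O)C(NC(C)=O)=C(C)C`: 148 nM

Going by the values given here, in an assay on isolated protein for inhibition of legumain (Mus musculus), read by fluorescence, with stated times of 30 s and 2.5 h (on this read-out higher numbers stand for weaker inhibition and lower numbers for stronger inhibition), compound 2 stands lowest of the two numbers, with compound 1 as its only neighbour; the single measured step, a 4.3-fold lower number from compound 1 to compound 2 (0.63 log units; beyond the scatter), exchanged a ring-bearing group for an acyclic one on the same carbonyl carbon. Compound 3, `CCOC(=O)/C=C/C(=O)N(CC(N)=O)NC(=O)[C@@H]1CCCN1C(=O)c1cccc(NC(C)=O)c1`, differs from compound 2 by a group of 10 heavy atoms (8 carbon, 1 nitrogen, 1 oxygen; one six-membered aromatic ring of carbon only) in place of a group of 8 heavy atoms (6 carbon, 1 nitrogen, 1 oxygen; no ring), on a carbonyl carbon. That earlier step bears only loosely on this change, which brings a ring back, now aromatic, while keeping the acetamido group. Compound 3 is therefore expected to show a 1.2-fold lower number from compound 2 to compound 3 (0.09 log units; within the scatter) in this assay. Compound 3 is estimated at 120 nM, between 40 nM and 400 nM.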

Compound 3, half-maximal inhibitory concentration: > 1000 nM
Compound 3: a limit, no number (the forecaster's own chance of this, stated with the estimate: 3%); middle value at least 8.3-fold (0.92 log units) away from the limit.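

For compound 3, this assay gives a limit and not a number: the limit of > 1000 nM in this assay, at which 1 of the 3 values shown sits.

Keeping the acetamido group on a 3-acetamidophenyl ring at this carbonyl carbon does not hold the earlier result, the change giving an at least 6.7-fold higher number from compound 2 to compound 3 (0.82 log units; beyond the scatter). The other step, an at least 1.5-fold higher number from compound 1 to compound 3 (0.19 log units; that floor lies within the scatter), has a floor that settles no order between those two compounds.

The values at hand do not tell the aromatic ring itself apart from the acetamido group on it. Going by these compounds alone, no compound measured here carries that ring without that group. A plain phenyl or a saturated cyclohexyl group on the same carbonyl carbon would separate these two.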